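The compounds below may be only part of what the source reports. "The series", "measured", "known", "first", "only" and "open" are said of these compounds alone.

Three compounds share one core and differ only in the group attached at its edge. Compound 1 `Cc1ccc2[nH]c(=O)c(/C=N/Nc3ccc([N+](=O)[O-])cc3)cc2c1` and compound 2 `Cc1ccc2[nH]c(=O)c(/C=N/Nc3ccc([N+](=O)[O-])cc3[N+](=O)[O-])cc2c1` carry a larger aromatic appendage, while compound 3 `Cc1ccc2[nH]c(=O)c(/C=N/CCO)cc2c1` carries a short chain instead. In a functional assay, read by spectrophotometry, with a stated time of 5 min (on this read-out higher numbers stand for weaker inhibition and lower numbers for stronger inhibition), compound 3 gives 1480000 nM, a very weak result. In this assay compound 1 gives "not active" (no number reported). Compound 2 likewise gives "not active" (no number reported) in this assay, so no number stands for compound 2; it shares that outcome with one other compound and cannot be ranked against compound 3 by size. Compound 4 `O=c1[nH]c2ccccc2cc1/C=N/Nc1ccc([N+](=O)[O-])cc1[N+](=O)[O-]` is compound 2 with a single change: hydrogen in place of methyl on an aromatic carbon. Going by the values given here, no step between measured compounds exists to gauge such a change here. Among the compounds with values here, with both aromatic-appendage compounds inactive and the only numbered compound very weak, no movement beyond the scatter is expected in either direction. Compound 4 is therefore expected to give about 2000000 nM in this assay, within 300000 nM to 20000000 nM, with a strong chance that no number is reported at all.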

Compound 4, half-maximal inhibitory concentration: "not active" (no number reported)
Compound 4 has no reported number here, so the estimate cannot be set against anything.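

In this assay compound 2 gives "not active" (no number reported) and compound 4 gives "not active" (no number reported) as well, so no step can be read between them. The compounds shown leave open whether swapping methyl for hydrogen changes inhibition at all. No supporting evidence bears on this outcome.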